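Diethyldithiocarbamate ketone series: cytotoxicity on a breast cancer line

A few compounds are considered here, and "the series" means these few. Any claim that something is new, unique, unknown or untested is made for them only; others in the source may bear on it.

Measured so far:
compound 1 `CCN(CC)C(=S)SC(CC(=O)c1ccccc1)c1ccc(Cl)cc1` gives 120 nM
compound 2 `CCN(CC)C(=S)SC(CC(=O)c1ccccc1)c1ccccc1Cl` gives 4500 nM
compound 3 `CCN(CC)C(=S)SC(CC(=O)c1ccc(OC)cc1)c1ccccc1Cl` gives 70 nM

The read-out throughout is a functional assay on MCF7 cells (Homo sapiens) for cytotoxicity, read by MTT assay, with a stated time of 48 h; a higher number here means a weaker inhibitor, a lower number a stronger inhibitor. Two changes start from compound 2. One is 4-chlorophenyl in place of 2-chlorophenyl on a saturated chain carbon bound to a saturated chain carbon and a sulfur, and the step it made is a 38-fold lower number from compound 2 to compound 1 (1.57 log units; beyond the scatter). The other is methoxy in place of hydrogen on an aromatic carbon, with the step of a 64-fold lower number from compound 2 to compound 3 (1.81 log units; beyond the scatter). Compounds 1 and 3 end up close to one another; their gap is within the scatter, so neither is put ahead of the other.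

Compound 4 `CCN(CC)C(=S)SC(CC(=O)c1ccc(OC)cc1)c1ccc(Cl)cc1` remains to be measured in this assay. It differs from compound 3 by 4-chlorophenyl in place of 2-chlorophenyl on a saturated chain carbon bound to a saturated chain carbon and a sulfur. The same change, word for word in its place, is the one from compound 2 to compound 1, so the two are the same change; the two cores differ by the methoxy difference described above. The change has been seen once only, so its transfer to the core of compound 3 rests on a single step, and whether the two gains combine cannot be checked from three compounds.

The step from compound 3 to compound 4 is estimated at a 5.8-fold lower number from compound 3 to compound 4 (0.77 log units; beyond the scatter), smaller than the earlier one. It is expected to be smaller because compound 3 already starts low at 70 nM. Compound 4 is expected to give about 12 nM. The range expected for compound 4 runs from 2 nM to 60 nM.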

Compound 4, half-maximal inhibitory concentration: 16000 nM
Compound 4: middle estimate off by 1300-fold (3.12 log units), on the low side; the measured number lies above the stated range.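

In this assay, among the compounds shown here, 4-chlorophenyl in place of 2-chlorophenyl on a saturated chain carbon bound to a saturated chain carbon and a sulfur does not carry to the methoxy core, where it gives a 230-fold higher number from compound 3 to compound 4 (2.36 log units; beyond the scatter), in the opposite direction to the earlier step: the same change on two cores in this assay, a 38-fold lower number (1.57 log units; beyond the scatter) from compound 2 to compound 1 and a 230-fold higher number (2.36 log units; beyond the scatter) from compound 3 to compound 4, 8600-fold (3.93 log units) apart, beyond the scatter of two such steps Methoxy in place of hydrogen on an aromatic carbon reverses in the same way, giving a 130-fold higher number from compound 1 to compound 4 (2.12 log units; beyond the scatter) on the core of compound 1: the same change on two cores in this assay, a 64-fold lower number (1.81 log units; beyond the scatter) from compound 2 to compound 3 and a 130-fold higher number (2.12 log units; beyond the scatter) from compound 1 to compound 4, 8600-fold (3.93 log units) apart, beyond the scatter of two such steps Neither change therefore has a fixed step that can be moved from one core to another in this set, and the two gains seen on compound 2 do not add, but both reversals hang on the single value of compound 4, so they count as one observation and say nothing of the reason or of how far the behaviour extends.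

Still open, on these data alone, is whether the loss belongs to methoxy and 4-chlorophenyl as a specific pair, or would recur with ethoxy or a hydroxyl in place of the methoxy, or bromine in place of the chlorine. Also open, as far as these compounds go, is whether a longer chain between the ketone and the dithiocarbamate carbon would keep the same reversal.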